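Opening a Carboxycyclopentyl Ring in a Leukotriene Receptor Antagonist Series

A few compounds are considered here, and "the series" means these few. Any claim that something is new, unique, unknown or untested is made for them only; others in the source may bear on it.

Measured compounds:
compound 1, `CC(CCc1nnn[nH]1)Cc1ccc(OCc2ccc3ccccc3n2)cc1`, 12 nM
compound 2, `O=C(O)C1CCC(c2ccc(OCc3ccc4ccccc4n3)cc2)C1`, 43 nM

Two compounds have been characterised in an assay on membranes from lung (Cavia porcellus) for binding affinity to cysteinyl leukotriene receptor (Homo sapiens); a higher number here means a weaker inhibitor, a lower number a stronger inhibitor. Compound 1 gives 12 nM, while compound 2 gives 43 nM. Compound 2 therefore stands at the higher of the two numbers, the weaker inhibitor of the pair, and its gap to compound 1 lies beyond the usual scatter.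

Compound 3, `CC(CCC(=O)O)Cc1ccc(OCc2ccc3ccccc3n2)cc1`, is the next compound to be examined in this assay. It differs from compound 2 in one place: 4-carboxy-2-methylbutyl in place of 3-carboxycyclopentyl on an aromatic carbon. Within the data shown here, no step between measured compounds covers this kind of change, so there is no direct precedent on which to lean.

The expectation for compound 3 is a step of a 1.1-fold lower number from compound 2 to compound 3 (0.03 log units; within the scatter), not beyond the scatter, in either direction. Compound 3 is accordingly estimated at 40 nM in this assay, with a plausible range from 12 nM to 130 nM.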

Compound 3, inhibition constant: 43 nM
Compound 3: the middle estimate sits 1.1-fold (0.03 log units) below what was measured, within the range that was stated.
By their numbers in this assay, from the lowest: compound 1; then compounds 2 and 3 (each within the scatter of the next).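

Replacing 3-carboxycyclopentyl with 4-carboxy-2-methylbutyl gives no change at the digits printed from compound 2 to compound 3 (within the scatter) in this assay, so across these two compounds, opening the five-membered ring on this aromatic carbon leaves the reading unmoved. Compound 3 also allows a comparison with compound 1 that differs in one place: carboxy in place of 1H-tetrazol-5-yl gives a 3.6-fold higher number from compound 1 to compound 3 (0.55 log units; beyond the scatter), so the group at the chain end registers in this assay where the ring opening did not. Nothing measured here explains either step.

The compounds shown leave open whether a 1H-tetrazol-5-yl group on the five-membered ring would give the same step as it does on the chain. They also leave open how a longer chain, a primary amide or a sulfonamide at the chain end would read, and whether the methyl branch of 4-carboxy-2-methylbutyl contributes at all.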